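Chloro addition to the benzyl ester analogue

The source may report more compounds than this note shows. Statements on the series, on what has been measured and on what is new or still open speak of the compounds shown alone.

Measured compounds:
compound 1 `COc1ccc2[nH]c(-c3cn(-c4ccccc4)nc3-c3ccccc3)nc2c1` — 1230 nM
compound 2 `O=C(OCc1ccccc1)c1ccc2[nH]c(-c3cn(-c4ccccc4)nc3-c3ccccc3)nc2c1` — 19300 nM

In a functional assay on A549 cells (Homo sapiens) for antiproliferative activity, read by MTT assay, with a stated time of 48 h (on this read-out lower numbers stand for stronger inhibition and higher numbers for weaker inhibition), compound 1 gives 1230 nM, and compound 2 gives 19300 nM, the highest number of the two, with a 16-fold higher number from compound 1 to compound 2 (1.20 log units; beyond the scatter). Compound 3 `O=C(OCc1ccccc1)c1ccc2[nH]c(-c3cn(-c4ccccc4)nc3-c3ccc(Cl)cc3)nc2c1` carries the change (chloro in place of hydrogen on an aromatic carbon). No measured step bears on this position; the only step shown, a 16-fold higher number from compound 1 to compound 2 (1.20 log units; beyond the scatter), concerns a different site. With nothing to go on, the step of a 1.3-fold lower number from compound 2 to compound 3 (0.11 log units; within the scatter) is expected to stay within the scatter. Compound 3 is estimated at 15000 nM, in the range 5000 nM to 45000 nM.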

Compound 3, half-maximal inhibitory concentration: 7730 nM
Beside the measured number, compound 3's estimate is 1.9-fold (0.29 log units) above it; the range from low to high includes it.
By their numbers in this assay, from the lowest: compound 1; then compound 3; then compound 2.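

In this assay, among these compounds, the change from phenyl to 4-chlorophenyl gives a 2.5-fold lower number from compound 2 to compound 3 (0.40 log units; beyond the scatter), the first reading on this position. The ring para to a large group therefore responds to substitution, and chloro moves the number towards stronger inhibition in the benzyl ester setting. Nothing available explains this step.

From the compounds shown here alone, whether chloro gives a similar step with methoxy in place of benzyloxycarbonyl remains open. So does the outcome with fluoro, methoxy or an amine at this same place on the ring.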